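From a limit reading to a new side-chain ring

The compounds below may be only part of what the source reports. "The series", "measured", "known", "first", "only" and "open" are said of these compounds alone.

Compound 2 `CN(C(=O)CCc1cn(-c2ccc(Br)cc2)nc1-c1ccc(Cl)cc1)S(C)(=O)=O` reads < 5000 nM in a physicochemical assay for solubility, in phosphate buffer, measured as thermodynamic solubility, at pH 7.4 (on this read-out higher numbers stand for higher solubility and lower numbers for lower solubility), and that reading is a limit of the assay, not a number. Among the compounds with values here, the only true number comes from compound 1 `CS(=O)(=O)NC(=O)CCc1cn(-c2ccc(Br)cc2)nc1Cc1ccccc1`, which gives 200000 nM in this assay and differs from compound 2 in more than one place.

Compound 3 `O=c1[nH]nc(CCc2cn(-c3ccc(Br)cc3)nc2-c2ccc(Cl)cc2)o1` keeps the shared core of compound 2 and changes in one place (a group of 6 heavy atoms (2 carbon, 2 nitrogen, 2 oxygen; one five-membered aromatic ring with 3 hetero atoms) in place of a group of 8 heavy atoms (3 carbon, 1 nitrogen, 3 oxygen, 1 sulfur; no ring), on a saturated chain carbon, two bonds along the chain from an aromatic carbon). On a saturated chain carbon, two bonds along the chain from an aromatic carbon, the methyl(methylsulfonyl)carbamoyl group gives way to a group with one five-membered aromatic ring with 3 hetero atoms.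

Within the data shown here, no measured step covers this exchange, so any expectation is loose. Among the measured compounds shown here, a moderate upward move in this assay is expected, beyond the usual scatter, and it rests on compound 1 at 200000 nM as the one true number. The estimated step, an at least 6.0-fold higher number from compound 2 to compound 3 (0.77 log units; beyond the scatter), is uncertain in size given that its starting point is only a limit. For compound 3 the expected value is 30000 nM, with an estimated range from 6000 nM to 150000 nM, and the measurement is still to come.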

Compound 3, solubility: < 5000 nM
Compound 3 ended at the assay's limit; the forecaster's own chance of this, stated with the estimate: 20%; middle value at least 6.0-fold (0.77 log units) from the limit.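

Compound 3 reads < 5000 nM in this assay, which is a limit of the assay and not a number. Compound 2 also stands at a limit, so no step between the two compounds can be read: the limit of < 5000 nM in this assay, at which 2 of the 3 values shown sit.

The compounds shown leave open how the methyl(methylsulfonyl)carbamoyl group and the ring that replaces it in compound 3 compare in this assay.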